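Swapping a Small Aromatic Ring for an Open Amide

The compounds below may be only part of what the source reports. "The series", "measured", "known", "first", "only" and "open" are said of these compounds alone.

Compound 2 `CC(C)C(c1ncc[nH]1)c1ccc(-c2ccc3cccc(F)c3c2)[nH]c1=O` and compound 1 `CC(C)C(c1ccc(-c2ccc3cccc(F)c3c2)[nH]c1=O)N1CCN/C1=N\C#N` share one core. In a physicochemical assay for solubility, measured as kinetic solubility, at pH 2 (on this read-out lower numbers stand for lower solubility and higher numbers for higher solubility), compound 1 gives 32500 nM, and compound 2 gives 31800 nM; the step of a 1.0-fold lower number from compound 1 to compound 2 (0.01 log units; within the scatter) leaves the pair within the scatter, so compound 2 stands alongside compound 1 with two numbers that cannot be told apart. Compound 3 `CC(C)C(CC(N)=O)c1ccc(-c2ccc3cccc(F)c3c2)[nH]c1=O` differs from compound 2 by carbamoylmethyl in place of 1H-imidazol-2-yl on a saturated chain carbon bound to an aromatic carbon and a saturated chain carbon. Among the compounds with values here, no measured step covers this kind of change; the one step known, exchanging one five-membered ring for another, was flat. Compound 3 is therefore expected to show no step beyond the scatter, a 1.1-fold lower number from compound 2 to compound 3 (0.03 log units; within the scatter), with an estimated 30000 nM between 15000 nM and 60000 nM.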

Compound 3, solubility: 3120 nM
For compound 3 the middle estimate is 9.6-fold (0.98 log units) above the measured one, and the stated range ends above it.
By their numbers in this assay, from the lowest: compound 3; then compounds 2 and 1 (each within the scatter of the next).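

At this saturated chain carbon the choice of group does matter: in this assay, carbamoylmethyl in place of 1H-imidazol-2-yl gives a 10-fold lower number from compound 2 to compound 3 (1.01 log units; beyond the scatter), and the same open group in place of the larger ring-bearing group gives a 10-fold lower number from compound 1 to compound 3 (1.02 log units; beyond the scatter). The two ring-bearing groups remain within the scatter of each other, and only the group without a ring stands apart. Going by these compounds, whether the step follows the loss of a ring or the carbamoyl end itself stays open; an amine, a carboxylic acid or a longer chain on this carbon could separate the two. No measurement shown accounts for the step.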